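A methoxy added to the anilide ring of compound 3

This account rests on a few compounds, and the source may have more. Where it says the series, first, only, none or still open, it means among the compounds named here.

Three measured compounds share a core and differ at a carbonyl carbon. Compound 1 `COc1cc(-c2nnc(SCC(=O)c3ccc(F)c(F)c3)n2N)cc(OC)c1OC` gives in a functional assay on PC-3 cells (Homo sapiens) for antiproliferative activity, read by MTT assay, with a stated time of 48 h (on this read-out lower numbers stand for stronger inhibition and higher numbers for weaker inhibition), only a limit, > 100000 nM. Compound 2 `COc1ccc(C(=O)CSc2nnc(-c3cc(OC)c(OC)c(OC)c3)n2N)cc1` gives in this assay 97900 nM. Compound 3 `COc1cc(-c2nnc(SCC(=O)Nc3ccccc3)n2N)cc(OC)c1OC` gives in this assay 37900 nM, the lowest of the two numbers, and the step of a 2.6-fold lower number from compound 2 to compound 3 (0.41 log units; beyond the scatter) lies beyond the scatter. Compound 4 `COc1cccc(NC(=O)CSc2nnc(-c3cc(OC)c(OC)c(OC)c3)n2N)c1` is not yet measured; it differs from compound 3 by methoxy in place of hydrogen on an aromatic carbon. Going by the values given here, no measured step alters a substituent on that ring; the nearest comparisons are an at least 1.0-fold lower number from compound 1 to compound 2 (0.00 log units; that floor lies within the scatter), where a methoxy entered on a different aryl group, and an at least 2.6-fold lower number from compound 1 to compound 3 (0.42 log units; beyond the scatter). Compound 4 is therefore expected to show a 1.1-fold lower number from compound 3 to compound 4 (0.03 log units; within the scatter), no step beyond the scatter. Compound 4 is estimated at 35000 nM, between 12000 nM and 100000 nM.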

Compound 4, half-maximal inhibitory concentration: > 100000 nM
Compound 4: no number, only a limit (the forecaster's own chance of this, stated with the estimate: 15%); middle value at least 2.8-fold (0.45 log units) from the limit.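

Going by these compounds alone, the anilide ring, which no earlier step had touched, proves responsive in this assay: 3-methoxyphenyl in place of phenyl, with the methoxy meta to a large group, gives an at least 2.6-fold higher number from compound 3 to compound 4 (0.42 log units; beyond the scatter). Compound 4 reports only a limit, so this step has a floor and no exact size. The edge that anilino gave compound 3 over compound 2 does not survive this methoxy, as the comparison with the 4-methoxyphenyl ketone shows an at least 1.0-fold higher number from compound 2 to compound 4 (0.00 log units; that floor lies within the scatter).

From the compounds shown here alone, the step from compound 1 to compound 4 cannot be read, and the full size of the other two steps stays open at the limit: the limit of > 100000 nM in this assay, at which 2 of the 4 values shown sit. Whether a fluorine, a hydroxyl or an amine at this place would be tolerated also stays open.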